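The source may hold more compounds than are shown below. What is called first, only, known or untested is meant among the compounds shown, and "the series" means these compounds.

Compound 1 `CC(C)c1ccc(-c2nc(SCc3cn(CC(=O)NC(=O)Nc4ccccn4)nn3)nc(Nc3ccccc3Cl)c2C#N)cc1` in a functional assay on MCF7 cells (Homo sapiens) for inhibition, read by MTT assay, with a stated time of 72 h (a lower number here means a stronger inhibitor, a higher number a weaker inhibitor), gives 43700 nM.
Compound 2 `CC(C)c1ccc(-c2nc(SCc3cn(CC(=O)NC(=O)Nc4ccccn4)nn3)nc(Nc3ccc(F)cc3)c2C#N)cc1` gives only a limit, > 64000 nM; this is the limit of > 64000 nM in this assay, at which 1 of the 3 values shown sits.
Compound 3 `CC(C)c1ccc(-c2nc(SCc3cn(CC(=O)NC(=O)Nc4ccccn4)nn3)nc(Nc3cccc(Cl)c3)c2C#N)cc1` gives 18000 nM.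

Compound 3 stands lowest of the two numbers; its nearest neighbour is reached by the step of a 2.4-fold lower number from compound 1 to compound 3 (0.39 log units; beyond the scatter). The move from the limit of compound 2 is an at least 3.5-fold lower number from compound 2 to compound 3 (0.55 log units; beyond the scatter), and the remaining measured step, an at least 1.4-fold higher number from compound 1 to compound 2 (0.16 log units; that floor lies within the scatter), sits at a floor within the scatter. All three measured steps change the aryl group on the nitrogen of the shared core by moving or exchanging a halogen; none of them keeps the 3-position and exchanges only the group that sits there.

Compound 4 `CC(C)c1ccc(-c2nc(SCc3cn(CC(=O)NC(=O)Nc4ccccn4)nn3)nc(Nc3cccc([N+](=O)[O-])c3)c2C#N)cc1` differs from compound 3 by nitro in place of chloro on an aromatic carbon. Within the data shown here, no measured step tests a nitro here, so the expectation rests on the observation that retaining the 3-substituted pattern of compound 3 gave the lowest number. A change of about a 1.2-fold lower number from compound 3 to compound 4 (0.08 log units; within the scatter) in this assay is expected, within or near the scatter. Compound 4 is thus estimated at 15000 nM, with a range from 6000 nM to 40000 nM.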

Compound 4, half-maximal inhibitory concentration: 25900 nM
Beside the measured number, compound 4's estimate is 1.7-fold (0.24 log units) below it; low and high end bracket the measured number.
By their numbers in this assay, from the lowest: compounds 3, 4 and 1 (each within the scatter of the next, the first and the last beyond it). At a limit, above all of these: compound 2.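

In this assay, among these compounds, the one exchange that keeps the substituent in place, a 1.4-fold higher number from compound 3 to compound 4 (0.16 log units; within the scatter), stays within the scatter, so 3-chlorophenyl and 3-nitrophenyl cannot be told apart here. The step of a 1.7-fold lower number from compound 1 to compound 4 (0.23 log units; within the scatter) also stays within the scatter, so 3-nitrophenyl does not separate from 2-chlorophenyl, although 3-chlorophenyl does. Compound 2 carries a limit of the assay and not a number, and the step of an at least 2.4-fold lower number from compound 2 to compound 4 (0.39 log units; beyond the scatter) lies beyond the scatter; nothing shown bears on the cause of these differences.

As far as these compounds go, whether an amine or a carboxylic acid on the aromatic carbon meta to a large group would read differently from chloro and nitro stays open. Also open, from the compounds shown here alone, is whether the fluoro of compound 2 or its place on the ring sets that compound apart.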